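Swapping formyl for 2-acetylethenyl in compound 1

This account rests on a few compounds, and the source may have more. Where it says the series, first, only, none or still open, it means among the compounds named here.

- Compound 1 `CC1(C)CCC[C@]2(C)[C@@H](C=O)C(C=O)=CC[C@@H]12` gives 65000 nM
- Compound 2 `CCOC(=O)/C=C/C1=CC[C@H]2C(C)(C)CCC[C@]2(C)[C@H]1C=O` gives 29000 nM
- Compound 3 `COC(=O)/C=C/C=C/C1=CC[C@H]2C(C)(C)CCC[C@]2(C)[C@H]1C=O` gives 25000 nM

These values come from a functional assay on SK-MEL-28 cells (Homo sapiens) for inhibition, read by MTT assay, with a stated time of 72 h (a lower number here means a stronger inhibitor of growth, a higher number a weaker inhibitor of growth), and compound 1 has the highest number of the three, which makes it the weakest inhibitor of growth here. Compound 4 `CC(=O)/C=C/C1=CC[C@H]2C(C)(C)CCC[C@]2(C)[C@H]1C=O` carries 2-acetylethenyl in place of formyl on a double-bonded ring carbon of the core of compound 1 and the change amounts to 2-acetylethenyl in place of formyl on a double-bonded ring carbon in all. The closest measured change is a 2.2-fold lower number from compound 1 to compound 2 (0.35 log units; beyond the scatter) with 2-(ethoxycarbonyl)ethenyl entering at that same place. The next measured change is a 1.2-fold lower number from compound 2 to compound 3 (0.06 log units; within the scatter) and this shows that swapping one such group for another did little in this small set. A modest step to a lower number is therefore expected in this assay and no large gain. The estimated step is a 2.4-fold lower number from compound 1 to compound 4 (0.38 log units; beyond the scatter) on this basis. For compound 4 the expected value is 27000 nM with an estimated range from 11000 nM to 60000 nM around it.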

Compound 4, concentration for 50% growth inhibition: 28000 nM
For compound 4 the middle estimate is 1.0-fold (0.02 log units) below the measured one, within the range that was stated.
By their numbers in this assay, from the lowest: compounds 3, 4 and 2 (each within the scatter of the next); then compound 1.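

In this assay there is a 2.3-fold lower number from compound 1 to compound 4 (0.37 log units; beyond the scatter), so the gain over formyl at this double-bonded ring carbon is not tied to an ester at the end of the chain: an acetyl end gives it too. What sits on the carbonyl carbon makes no difference that can be read here, as methyl in place of ethoxy gives a 1.0-fold lower number from compound 2 to compound 4 (0.02 log units; within the scatter). The step between the two chain lengths, a 1.1-fold higher number from compound 3 to compound 4 (0.05 log units; within the scatter), is also within the scatter, so compound 2, compound 3 and compound 4 cannot be ranked against one another.

Nothing available here explains these numbers. On these data alone, it remains open whether a carboxylic acid, an amide or an amine at the end of the chain would keep this level, and whether a saturated chain of the same length would do so.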